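A few compounds are considered here, and "the series" means these few. Any claim that something is new, unique, unknown or untested is made for them only; others in the source may bear on it.

Measured so far in a functional assay on CHO cells for agonist activity at sphingosine 1-phosphate receptor 5 (Homo sapiens), read by GTPgammaS binding; a lower number here means that less compound is needed, a higher number that more compound is needed for the effect:
Compound 1 `Cc1cc(C(=O)O)ccc1-c1noc(-c2ccc(C3CCCCC3)cc2)n1` gives > 10000 nM, which is a limit of the assay and not a number.
Compound 2 `Cc1cc(CCC(=O)O)ccc1-c1noc(-c2ccc(OC(C)C)c(C(F)(F)F)c2)n1` gives 40 nM.

Among the measured compounds shown here, compound 2 thus holds the only real number here; the other value is a limit (the limit of > 10000 nM in this assay, at which 1 of the 2 values shown sits). Compound 3 `COc1cc(-c2nc(-c3ccc(CCC(=O)O)cc3C)no2)ccc1OC(C)C` differs from compound 2 in one place: methoxy in place of trifluoromethyl on an aromatic carbon, ortho to an isopropoxy group. For the measured compounds named here, no measured pair shows this change, so the size of its effect is open. The change is expected to cost some potency, beyond the usual scatter, a step estimated at a 3.8-fold higher number from compound 2 to compound 3 (0.57 log units; beyond the scatter). Compound 3 is therefore expected to come out near 150 nM, most likely between 40 nM and 600 nM.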

Compound 3, half-maximal effective concentration: 270 nM
Compound 3: the middle estimate sits 1.8-fold (0.26 log units) below what was measured; measured number inside the range.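

Replacing trifluoromethyl with methoxy, ortho to an isopropoxy group, gives a 6.8-fold higher number from compound 2 to compound 3 (0.83 log units; beyond the scatter) in this assay and so shows that this one position affects potency. The loss is modest: compound 3 still gives a measurable value, so this position accepts methoxy, though less well than trifluoromethyl. Nothing measured here explains the difference.

One pair cannot show whether the trend extends to other groups at this position. A chlorine atom or a nitrile there could land near either compound or outside their range.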